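Methyl for fluoro on the aryl ring: a second look

This account rests on a few compounds, and the source may have more. Where it says the series, first, only, none or still open, it means among the compounds named here.

Measured compounds:
compound 1 `Fc1ccc(-c2csc(N/N=C/c3ccc(Cl)cc3Cl)n2)cc1` gives 94.6%
compound 2 `Cc1ccc(-c2csc(N/N=C/c3ccc(Cl)cc3Cl)n2)cc1` gives 93.3%
compound 3 `Fc1ccc(-c2csc(N/N=C/c3cccs3)n2)cc1` gives 94.6%

In a functional assay, read by spectrophotometry, with a stated time of 15 min, tested at 60 ug/mL (a higher number here means a stronger effect of the compound at the concentration tested, a lower number a weaker effect), compound 1 gives 94.6%. Compound 2 differs from compound 1 by methyl in place of fluoro on an aromatic carbon and in this assay compound 2 gives 93.3%, so the step is a number 1.3 percentage points lower from compound 1 to compound 2 (within the scatter). Compound 3 carries a different hydrazone part; the difference between the two cores is not broken down here. In this assay compound 3 gives 94.6%, which stands level with compound 1 at the digits printed, and its two values with compound 2 lie within the scatter of each other.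

Compound 4 `Cc1ccc(-c2csc(N/N=C/c3cccs3)n2)cc1` has not yet been measured. It differs from compound 3 by methyl in place of fluoro on an aromatic carbon, the same kind of change as from compound 1 to compound 2, made on the core of compound 3. Because the earlier step of a number 1.3 percentage points lower from compound 1 to compound 2 (within the scatter) lay within the scatter, the step from compound 3 to compound 4 is expected to be similarly small, a number 1.1 percentage points lower from compound 3 to compound 4 (within the scatter). Compound 4 is therefore expected to give 93.5% in this assay, with a plausible range from 86% to 98%. This rests on a single pair, compound 1 and compound 2, so the expectation is provisional.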

Compound 4, a percentage reported as inhibition, at one concentration (the size of the read-out at that concentration, not a potency): 97.6%
Compound 4: the middle estimate sits 4.1 percentage points below what was measured, and the stated range covers the measured number.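

In this assay, methyl in place of fluoro on the core of compound 3 gives a step that reads a number 3 percentage points higher from compound 3 to compound 4 (within the scatter). Set beside the earlier step, the change shows no difference between the two cores: the same change on two cores in this assay, a number 1.3 percentage points lower (within the scatter) from compound 1 to compound 2 and a number 3 percentage points higher (within the scatter) from compound 3 to compound 4, 4.3 percentage points apart, within the scatter of two such steps Within these two pairs, then, the swap of fluoro for methyl carries from one core to the other without a step or a gap that stands out from the scatter, but this does not show that the change is without effect in general, that the core plays no part in other changes, or that the compounds would show an effect of like strength at other concentrations, since the read-out is the size of the effect at one concentration and the comparison rests on only two cores.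

Open, going by these compounds, is whether a group other than fluoro or methyl in the same place, para to a large group, such as an amine, a carboxylic acid or a longer chain like butyl, would keep the inhibition at this level or take it beyond the scatter. Also open, on these data alone, is whether fluoro and methyl would still read alike on a third hydrazone part, or at a lower concentration, where a step between them might appear.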